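Methyl to Hydrogen on an Aromatic Oxygen: Compound 4

A few compounds are considered here, and "the series" means these few. Any claim that something is new, unique, unknown or untested is made for them only; others in the source may bear on it.

Compound 1 `COc1ccc(-c2cn(-c3ccc(OC(F)(F)F)cc3)nn2)cc1O`: > 10000 nM
Compound 2 `COc1ccc(-c2cn(-c3ccc(OC)c(OC)c3)nn2)cc1OC`: "not determined" (no result reported)
Compound 3 `COc1ccc(-c2cn(-c3ccc(OC(F)(F)F)cc3)nn2)cc1OC`: > 1000 nM

In a functional assay on MDA-MB-231 cells (Homo sapiens) for cytotoxicity, read by MTT assay (on this read-out lower numbers stand for stronger inhibition and higher numbers for weaker inhibition), compound 3 gives > 1000 nM, which is a limit of the assay rather than a number. Compound 1 gives > 10000 nM, again only a limit. For compound 2 no result was reported. Compound 1 arises from compound 3 through (hydrogen in place of methyl on an oxygen on an aromatic ring). The step that the two limits leave unreadable from compound 3 to compound 1 cannot be sized because the limit of > 1000 nM in this assay, at which 1 of the 3 values shown sits, and the limit of > 10000 nM in this assay, at which 1 of the 3 values shown sits, cap both compounds. Compound 4 `COc1ccc(-c2cn(-c3ccc(OC)c(OC)c3)nn2)cc1O` is the unmeasured partner of compound 2, reached by the same change, (hydrogen in place of methyl on an oxygen on an aromatic ring); the difference between the cores of compound 2 and compound 3 is not broken down here. With both measured relatives sitting at limits and compound 2 unmeasured, only a weak result is expected for compound 4 in this assay. The value for compound 4 is expected near 20000 nM. For compound 4 the expected span runs from 3000 nM to 100000 nM.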

Compound 4, half-maximal inhibitory concentration: > 100 nM
Compound 4: a limit, no number (the forecaster's own chance of this, stated with the estimate: 80%); the middle value does not contradict the limit.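

In this assay compound 4 gives > 100 nM, which is a limit of the assay and not a number. With no number for compound 2 either, no new step can be read between compound 2 and compound 4. The compounds shown leave open what number compound 4 would have, and whether going from methoxy to hydroxy changes the value on the core of compound 4.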